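The source may hold more compounds than are shown below. What is called first, only, known or untested is meant among the compounds shown, and "the series" means these compounds.

Compound 2 `Cc1ccc(/C=N/NC(=O)CSc2nnc(-c3ccncc3)o2)cc1` holds the higher of the two numbers recorded so far: in a functional assay on HepG2 cells (Homo sapiens) for cytotoxicity, read by MTT assay, with a stated time of 48 h (on this read-out lower numbers stand for stronger inhibition and higher numbers for weaker inhibition), compound 2 gives 10000 nM, whereas compound 1 `NNC(=O)CSc1nnc(-c2ccncc2)o1` gives 3260 nM, a gap that lies beyond the scatter. Compound 3 `O=C(CSc1nnc(-c2ccncc2)o1)N/N=C/c1ccc(Cl)cc1Cl` has not yet been tested in this assay. It differs from compound 2 in a single place: 2,4-dichlorophenyl in place of 4-methylphenyl on a carbon with a double bond to nitrogen. Among the compounds with values here, no measured pair shows a change of this kind, so the data give no direction for it. The step is expected to be modest, about a 1.3-fold lower number from compound 2 to compound 3 (0.10 log units; within the scatter), and may well fall within the scatter. Compound 3 is accordingly estimated at 8000 nM, with a range from 3000 nM to 20000 nM.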

Compound 3, half-maximal inhibitory concentration: 18600 nM
Compound 3: middle estimate off by 2.3-fold (0.37 log units), on the low side; measured number inside the range.
By their numbers in this assay, from the lowest: compound 1; then compounds 2 and 3 (each within the scatter of the next).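

At the carbon with a double bond to nitrogen, 2,4-dichlorophenyl in place of 4-methylphenyl gives a 1.9-fold higher number from compound 2 to compound 3 (0.27 log units; within the scatter) in this assay. Within the data shown here, this is the first reading of a change at this place, and it does not separate the two groups on this read-out. Nothing measured here accounts for the result. As far as these compounds go, it remains open whether an amine or a carboxylic acid on the phenyl ring, or a longer chain in place of that ring, would move the number beyond the scatter.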